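Aryl ester series: nitro for trifluoromethyl on the benzoate

A few compounds are considered here, and "the series" means these few. Any claim that something is new, unique, unknown or untested is made for them only; others in the source may bear on it.

Compound 1, `Cc1cc2c(C(C)C)ccc(C)c2cc1OC(=O)c1ccc(C(F)(F)F)cc1`: 28.7%
Compound 2, `CC1=CC[C@H](C(C)C)c2cc(C)c(OC(=O)c3ccc(C(F)(F)F)cc3)cc21`: "not active" (no number reported)

Among the compounds with values here, in a functional assay on SK-LU-1 cells (Homo sapiens) for antiproliferative activity, read by sulforhodamine B assay, with a stated time of 48 h, tested at 50 uM (a higher number here means more inhibition at the concentration tested (going by the name of the read-out), a lower number less inhibition), compound 1 gives 28.7%, the only number in hand. Within the data shown here, compound 2 is reported as "not active" (no number reported) with no figure, so the pair shows only that compound 1 reaches a measured level of inhibition while compound 2 does not. Compound 3, `Cc1cc2c(C(C)C)ccc(C)c2cc1OC(=O)c1ccc([N+](=O)[O-])cc1`, is unmeasured. It differs from compound 1 by nitro in place of trifluoromethyl on an aromatic carbon. Among the measured compounds shown here, no step between measured compounds sizes this change; for compound 3 the step is expected to stay within the scatter, with no set direction: a number 1.3 percentage points higher from compound 1 to compound 3 (within the scatter). Compound 3 is expected to give 30%, between 10% and 50%.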

Compound 3, a percentage reported as inhibition, at one concentration (the size of the read-out at that concentration, not a potency): 100%
Estimate against measurement, compound 3: 70 percentage points below; measured number outside the range, above it.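

In this assay, nitro in place of trifluoromethyl on this aromatic carbon, para to a large group, gives a number 71.3 percentage points higher from compound 1 to compound 3 (beyond the scatter). Inhibition on the shared core therefore depends strongly on the group at this one position, which compound 1 and compound 2 could not show, as they differ elsewhere. No measurement in hand gives a reason for the step.

As far as these compounds go, whether other groups here, such as an amine, a nitrile or a carboxylic acid, would match nitro stays open. Also open, from the compounds shown here alone, is whether nitro gives a similar step on the core of compound 2.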